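Halogen swap on the aryl end of a dienone

A few compounds are considered here, and "the series" means these few. Any claim that something is new, unique, unknown or untested is made for them only; others in the source may bear on it.

Measured so far:
Compound 1, `CC1=C(/C=C/C(=O)/C=C/c2ccc(Br)cc2)C(C)(C)CCC1`: 18900 nM
Compound 2, `CC1=C(/C=C/C(=O)/C=C/c2ccc(F)cc2)C(C)(C)CCC1`: 8200 nM

Both compounds share one core and differ only in the halogen on the aromatic ring. Among the measured compounds shown here, in a functional assay on PC-3 cells (Homo sapiens) for cytotoxicity, read by sulforhodamine B assay, with a stated time of 48 h (on this read-out lower numbers stand for stronger inhibition and higher numbers for weaker inhibition), compound 1 gives 18900 nM, the highest of the two numbers; its only neighbour is compound 2, which in this assay gives 8200 nM.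

Compound 3, `CC1=C(/C=C/C(=O)/C=C/c2ccccc2F)C(C)(C)CCC1`, has not yet been measured. Its change from compound 1 is 2-fluorophenyl in place of 4-bromophenyl on a double-bonded chain carbon bound to a double-bonded chain carbon.

For the measured compounds named here, the one measured step that bears on this change is a 2.3-fold lower number from compound 1 to compound 2 (0.36 log units; beyond the scatter). That step also exchanged bromo for fluoro, and it lowered the number by a modest amount, beyond the scatter. Going by the values given here, compound 3 carries the same halogen exchange, but the fluorine sits at a different ring position, and no measured pair shows what such a shift in position does. The expectation is therefore a modest fall in the number from compound 1 to compound 3, of roughly the size seen from compound 1 to compound 2, with a wide range to cover the unknown effect of position: compound 3 is expected to give 10000 nM, between 4000 nM and 25000 nM, a step of a 1.9-fold lower number from compound 1 to compound 3 (0.28 log units; within the scatter).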

Compound 3, half-maximal inhibitory concentration: 3400 nM
The estimate for compound 3 lay 2.9-fold (0.47 log units) above the measured number; measured number outside the range, below it.
By their numbers in this assay, from the lowest: compound 3; then compound 2; then compound 1.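

Moving the fluorine on the aromatic ring, with no change of halogen, matters in this assay: 2-fluorophenyl in place of 4-fluorophenyl gives a 2.4-fold lower number from compound 2 to compound 3 (0.38 log units; beyond the scatter) and so shows that where the halogen sits affects the number, which the earlier bromo-to-fluoro step could not reveal. Combining the change of halogen with the change of ring position, 2-fluorophenyl in place of 4-bromophenyl gives a 5.6-fold lower number from compound 1 to compound 3 (0.74 log units; beyond the scatter) and makes this the largest step among the three compounds, and compound 3 has the lowest number, with its steps to both of the others beyond the scatter. Nothing available here explains why this change of ring position lowers the number.

On these data alone, whether a bromo group would respond to the same move as fluoro remains open, as does what an amine or a carboxylic acid would do on the aromatic ring in place of the halogen. As far as these compounds go, all of these comparisons also rest on this assay alone, so whether the same order of the three compounds holds in other cells is unknown.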